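Working notes: the step from compound 3 to compound 4

This account rests on a few compounds, and the source may have more. Where it says the series, first, only, none or still open, it means among the compounds named here.

Three compounds on the shared core carry numbers in an ADME assay on HEK293 cells for agonist activity at Toll-like receptor 8 (Homo sapiens), read by a luciferase reporter, with a stated time of 6 h; on this read-out lower numbers stand for an effect already at smaller amounts and higher numbers for an effect only at larger amounts of compound. Compound 1 `CC(C)CCNc1nc(N)nc2ccccc12` gives 2.11 uM. Compound 2 `CCCCNc1nc(N)nc2cc(C(=O)N(C)C)ccc12` gives 0.5 uM. Compound 3 `CCCCNc1nc(N)nc2ccc(F)cc12` gives 0.1 uM, the lowest of the three numbers; compound 2 stands nearest to it and compound 1 furthest, and both gaps lie beyond the usual scatter. Within the data shown here, no two of the measured compounds differ in one place only, so no single structural step is isolated within the measured set.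

Compound 4 `CCCCNc1nc(N)nc2ccc(CCc3ccccn3)cc12` has not yet been measured in this assay. It differs from compound 3 as follows: 2-(pyridin-2-yl)ethyl in place of fluoro on an aromatic carbon. The group that enters is much larger than the one that leaves and carries a ring of its own; nothing among compounds 1 to 3 shows what such a group does at that place on the core. The expectation is a moderate step in this assay towards higher numbers, a 3.0-fold higher number from compound 3 to compound 4 (0.48 log units; beyond the scatter), with wide uncertainty. Compound 4 is estimated at 0.3 uM, with a range from 0.05 uM to 2 uM.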

Compound 4, minimum effective concentration: 0.3 uM
For compound 4 middle estimate and measured number coincide at the digits printed; measured number inside the range.
By their numbers in this assay, from the lowest: compound 3; then compounds 4 and 2 (each within the scatter of the next); then compound 1.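

In this assay, 2-(pyridin-2-yl)ethyl in place of fluoro on this aromatic carbon gives a 3.0-fold higher number from compound 3 to compound 4 (0.48 log units; beyond the scatter), a modest step. Among these compounds, this is the first direct reading at this position: the entering group is much larger than the leaving one and carries a ring of its own, yet compound 4 still gives 0.3 uM and ranks within the scatter of compound 2 in the series. No evidence at hand bears on what lies behind the step.

A single step cannot separate the contribution of the two-carbon linker from that of the pyridine ring. A plain ethyl group or a 2-phenylethyl group at the same place would be needed to tell the chain, the ring and the ring nitrogen apart, and a pyridin-4-yl isomer would test where that nitrogen sits.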